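Imidazole in Place of Pyrazole on a Shared Core

The compounds below may be only part of what the source reports. "The series", "measured", "known", "first", "only" and "open" are said of these compounds alone.

Compounds measured in an assay on isolated protein for inhibition of tyrosine-protein kinase receptor UFO (Homo sapiens), read by LC-MS; a lower number here means a stronger inhibitor, a higher number a weaker inhibitor:
compound 1, `Cc1nn(C)c(C)c1-c1ccc(-c2nnc(N(C)Cc3ccc4nccn4c3)o2)c(Cl)c1`, gives 79.4 nM.
compound 2, `Cc1nn(C)c(C)c1-c1ccc(-c2nnc(N(C)Cc3ccc4nccn4c3)o2)c(C#N)c1`, reaches only the assay limit of > 100000 nM.
compound 3, `Cc1cc(-c2c(C)n[nH]c2C)ccc1-c1nnc(N(C)Cc2ccc3nccn3c2)o1`, gives 5010 nM.

Compound 3 stands at the highest of the two numbers that are numbers; its nearest neighbour is compound 1, which lies well beyond the scatter below it, while compound 2 sits at a limit of > 100000 nM in this assay, at which 1 of the 3 values shown sits, and is not a number.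

Compound 4, `Cc1cc(-c2c(C)nc(C)n2C)ccc1-c1nnc(N(C)Cc2ccc3nccn3c2)o1`, is not yet measured. It differs from compound 3 in one place: 1,2,4-trimethyl-1H-imidazol-5-yl in place of 3,5-dimethyl-1H-pyrazol-4-yl on an aromatic carbon.

The only measured step among these compounds is an at least 1200-fold higher number from compound 1 to compound 2 (3.10 log units; beyond the scatter), and it concerns a different position on the core, so it says nothing directly about the change from compound 3 to compound 4. Compound 1 and compound 3 differ in two places at once, so their gap cannot be assigned to either one.

Going by the values given here, with no step that bears on the change, compound 4 is expected to lie near compound 3, with a wide margin: the estimate is 3000 nM, between 400 nM and 20000 nM, a step of a 1.7-fold lower number from compound 3 to compound 4 (0.22 log units; within the scatter) that is expected to stay within the scatter.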

Compound 4, half-maximal inhibitory concentration: 3980 nM
Beside the measured number, compound 4's estimate is 1.3-fold (0.12 log units) below it, within the range that was stated.
By their numbers in this assay, from the lowest: compound 1; then compounds 4 and 3 (each within the scatter of the next). At a limit, above all of these: compound 2.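

In this assay, 1,2,4-trimethyl-1H-imidazol-5-yl in place of 3,5-dimethyl-1H-pyrazol-4-yl gives a 1.3-fold lower number from compound 3 to compound 4 (0.10 log units; within the scatter), the first step shown at this position, on an aromatic carbon para to a large group; the earlier step concerned a different place on the shared core. The exchange takes the group from 1 hydrogen-bond donor to 0 hydrogen-bond donors and from 7 to 8 heavy atoms, yet the two compounds cannot be told apart in this read-out, so at this position and on this core the donor of the leaving group is not required to keep the number where it stands. Nothing measured here offers a reason why the two groups match.

From the compounds shown here alone, it remains open whether the same exchange would also leave the number unchanged on a core carrying chloro in place of the methyl group. Going by these compounds, what a primary amine or a carboxylic acid on the five-membered aromatic ring would do at this position, in place of one of its methyl groups, also remains open.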